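The source may report more compounds than this note shows. Statements on the series, on what has been measured and on what is new or still open speak of the compounds shown alone.

Working notes on the series. Compound 1 `CC1=C(C(=O)OCc2ccccc2)C(c2ccco2)NC(=S)N1` and compound 2 `CC1=C(C(=O)OCc2ccccc2)C(c2ccoc2)NC(=S)N1` share one core; compound 3 `COC(=O)C1=C(C)N(C)C(=O)NC1c1ccco1` and compound 4 `COC(=O)C1=C(C)N(C)C(=O)NC1c1ccoc1` share another, and the difference between the two cores is not broken down here. In an assay on membranes from HeLa cells for displacement of a labelled ligand from adenosine receptor A3 (Homo sapiens), read by scintillation counting, with a stated time of 180 min, tested at 1 uM (on this read-out lower numbers stand for less inhibition and higher numbers for more inhibition at the one concentration tested (going by the name of the read-out)), compound 1 gives 4%, compound 2 gives 20%, and compound 3 gives 9%. Compound 3 and compound 1 read within the scatter of each other, so no order is drawn between them. The change furan-3-yl in place of furan-2-yl on a saturated ring carbon made a step of a number 16 percentage points higher from compound 1 to compound 2 (beyond the scatter). The same kind of change, (furan-3-yl in place of furan-2-yl on a saturated ring carbon), leads to compound 4; the surroundings differ in their description: in the first pair the place is next to the ring atom that bears a large group, in the second pair it is next to the ring atom that bears a methoxycarbonyl group and three ring bonds from the ring atom that bears a methyl group. For the measured compounds named here, compound 4 is therefore expected to show a step of a number 10 percentage points higher from compound 3 to compound 4 (within the scatter), an expectation that rests on the one earlier step because a number 16 percentage points higher from compound 1 to compound 2 (beyond the scatter) is the only measured instance of this change. Compound 4 is estimated at 19%, with a likely range from 4% to 36%.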

Compound 4, a percentage reported as inhibition, at one concentration (the size of the read-out at that concentration, not a potency): 7%
Estimate against measurement, compound 4: 12 percentage points above; low and high end bracket the measured number.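

In this assay, furan-3-yl in place of furan-2-yl on a saturated ring carbon gives a number 2 percentage points lower from compound 3 to compound 4 (within the scatter), so on the core of compound 3 this change shows no readable effect. The step does not carry over unchanged between the two cores on this read-out: the same change on two cores in this assay, a number 16 percentage points higher (beyond the scatter) from compound 1 to compound 2 and a number 2 percentage points lower (within the scatter) from compound 3 to compound 4, 18 percentage points apart, beyond the scatter of two such steps

This shows that the step seen on the core of compound 1 cannot be assumed on the core of compound 3, but with one pair per core it does not show which difference between the cores goes with the gap, or how the change would behave on any further core. The compounds shown leave open how a phenyl or thiophene ring would read in place of the furan on that saturated ring carbon, and how a carboxylic acid or an amide would read in place of the ester. Going by these compounds, all four readings also come from a single concentration, so the potency of each compound on this receptor remains open.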